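The source may report more compounds than this note shows. Statements on the series, on what has been measured and on what is new or still open speak of the compounds shown alone.

Compound 1, `COc1cccc(-c2nc3ncccc3o2)c1`: 14%
Compound 2, `N#Cc1cccc(-c2nc3ncccc3o2)c1`: 21%
Compound 3, `O=[N+]([O-])c1cccc(-c2nc3ncccc3o2)c1`: 21%

Among the compounds with values here, all three share the same core and differ only in the single group that sits on an aromatic carbon of a six-membered aromatic ring of carbon only. In a functional assay on the whole organism for inhibition, with Rattus norvegicus as the target, at a dose of 30 mg/kg (a higher number here means more inhibition at the dose given (going by the name of the read-out), a lower number less inhibition), compound 3 gives 21%, level with compound 2 at the digits reported, and together these two are the highest of the three numbers. Yet the step of no change at the digits printed from compound 2 to compound 3 (within the scatter) and the step of a number 7 percentage points higher from compound 1 to compound 3 (within the scatter) both lie within the usual scatter, so the number of compound 3 cannot be called higher than that of either compound 1 or compound 2; the three numbers cannot be told apart.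

Compound 4, `Clc1cccc(-c2nc3ncccc3o2)c1`, has not yet been tested. It differs from compound 3 in one place: chloro in place of nitro on an aromatic carbon. Within the data shown here, no measured step involves a chloro group, so the only guide is how the earlier swaps at this same carbon behaved: a number 7 percentage points higher from compound 1 to compound 2 (within the scatter), a number 7 percentage points higher from compound 1 to compound 3 (within the scatter) and no change at the digits printed from compound 2 to compound 3 (within the scatter). Each stayed within the scatter, so no step beyond the scatter is expected here either, and the expected step is a number 2 percentage points lower from compound 3 to compound 4 (within the scatter). Compound 4 is therefore estimated at 19%, with a range from 8% to 32%.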

Compound 4, a percentage reported as inhibition, in the whole organism at one dose (the size of the read-out at that dose, not a potency): 32%
The estimate for compound 4 lay 13 percentage points below the measured number, and the stated range covers the measured number.
By their numbers in this assay, from the lowest: compounds 1, 2 and 3 (each within the scatter of the next); then compound 4.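

In this assay the group on this aromatic carbon now makes a difference that can be read: chloro in place of nitro gives a number 11 percentage points higher from compound 3 to compound 4 (beyond the scatter) and chloro in place of cyano gives a number 11 percentage points higher from compound 2 to compound 4 (beyond the scatter) while chloro in place of methoxy gives a number 18 percentage points higher from compound 1 to compound 4 (beyond the scatter) on the same shared core. Methoxy, cyano and nitro could not be told apart at this carbon, so chloro is the only one of the four groups that stands clear of all the others, although each of its three steps is modest in size. Nothing measured here bears on why chloro differs from the other three groups, so this remains an observation about these four compounds alone.

As far as these compounds go, whether an amine, a carboxylic acid, a longer chain or another halogen such as bromo on this carbon would read higher or lower than chloro stays open. Also open, from the compounds shown here alone, is whether chloro would give a similar step on another carbon of the same ring, or whether its lead over the other groups would hold at a different dose.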